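Replacing Isopropyl on the Amide Carbonyl with Methyl

The source may hold more compounds than are shown below. What is called first, only, known or untested is meant among the compounds shown, and "the series" means these compounds.

Measured in a functional assay on B16 cells (Mus musculus) for inhibition; on this read-out higher numbers stand for weaker inhibition and lower numbers for stronger inhibition:
- compound 1 `COc1cc(/C=C/C(=O)c2cccc(NC(=O)c3c(Cl)cccc3Cl)c2)ccc1O`: 1.58 ug/mL
- compound 2 `COc1cc(/C=C/C(=O)c2cccc(NC(=O)c3ccco3)c2)ccc1O`: 5.46 ug/mL
- compound 3 `COc1cc(/C=C/C(=O)c2cccc(NC(=O)C(C)C)c2)ccc1O`: 1.09 ug/mL

Compound 3 sits at the low end of these numbers, level with one other compound within the scatter, while the third stands clearly apart. The next compound, compound 4 `COc1cc(/C=C/C(=O)c2cccc(NC(C)=O)c2)ccc1O`, keeps the shared core and has methyl in place of isopropyl on a carbonyl carbon.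

For the measured compounds named here, two measured steps bear on this change, as both alter the group on that same carbonyl carbon. Isopropyl in place of 2,6-dichlorophenyl gave a 1.4-fold lower number from compound 1 to compound 3 (0.16 log units; within the scatter). Isopropyl in place of furan-2-yl gave a 5.0-fold lower number from compound 2 to compound 3 (0.70 log units; beyond the scatter). Going by the values given here, no measured step brings in methyl, so the data offer no direct precedent. The expectation rests on compound 3 at 1.09 ug/mL and on those two steps, one within the scatter and the other modest. In this assay, the expected step is small and leans towards a higher number: a 1.5-fold higher number from compound 3 to compound 4 (0.17 log units; within the scatter). The estimate for compound 4 is 1.6 ug/mL, with an expected range from 0.7 ug/mL to 4.5 ug/mL.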

Compound 4, half-maximal inhibitory concentration: 3.62 ug/mL
For compound 4 the middle estimate is 2.3-fold (0.35 log units) below the measured one; low and high end bracket the measured number.
By their numbers in this assay, from the lowest: compounds 3 and 1 (each within the scatter of the next); then compounds 4 and 2 (each within the scatter of the next).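

In this assay, the position proves sensitive to trimming the alkyl group, as methyl in place of isopropyl gives a 3.3-fold higher number from compound 3 to compound 4 (0.52 log units; beyond the scatter), so compound 4 does not stay level with compound 3. Set against the two ring-bearing amides, methyl gives a 1.5-fold lower number from compound 2 to compound 4 (0.18 log units; within the scatter), and also a 2.3-fold higher number from compound 1 to compound 4 (0.36 log units; beyond the scatter), which places compound 4 with the furan-2-yl amide and clear of the 2,6-dichlorophenyl amide. Across these four compounds, the number therefore does not simply track the size of the group, and nothing available here explains the loss on going to methyl.

Still open, as far as these compounds go, is whether ethyl or cyclopropyl on this carbonyl carbon would stay with isopropyl or drop to the level of methyl. It is also unknown how a tert-butyl group or a longer chain such as n-butyl would read at this position.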